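Swapping Trifluoromethyl for Methoxy on a Kinase Inhibitor Core

A few compounds are considered here, and "the series" means these few. Any claim that something is new, unique, unknown or untested is made for them only; others in the source may bear on it.

Of the compounds shown here, three have been tested in an assay on isolated protein for inhibition of tyrosine-protein kinase receptor UFO (Homo sapiens), read by FRET and Z'-LYTE, with a stated time of 1.5 h; on this read-out higher numbers stand for weaker inhibition and lower numbers for stronger inhibition. Compound 1 `Cc1c(C(=O)Nc2ccc(Oc3ncnc4[nH]cc(-c5ccccc5)c34)c(F)c2)c(=O)c2cc(C(F)(F)F)ccc2n1C` gives 150 nM, the highest of the three numbers. Compound 2 `Cc1ccc2c(c1)c(=O)c(C(=O)Nc1ccc(Oc3ncnc4[nH]cc(-c5ccccc5)c34)c(F)c1)c(-c1ccccc1)n2C` gives 78 nM, which lies within the scatter of compound 1. Compound 3 `CCc1ccc2c(c1)c(=O)c(C(=O)Nc1ccc(Oc3ccnc4[nH]cc(-c5ccccc5)c34)c(F)c1)c(C)n2C` gives 30 nM, a gap from compound 1 that lies beyond the scatter. The unmeasured compound 4 `COc1ccc2c(c1)c(=O)c(C(=O)Nc1ccc(Oc3ncnc4[nH]cc(-c5ccccc5)c34)c(F)c1)c(C)n2C` differs from compound 1 by methoxy in place of trifluoromethyl on an aromatic carbon. Among the measured compounds shown here, no measured pair isolates this change, so the direction rests on the spread seen among compounds 2 and 3, which lack the trifluoromethyl group. A modest fall in the number is expected, with the step of a 1.9-fold lower number from compound 1 to compound 4 (0.27 log units; within the scatter) from compound 1 to compound 4 near the edge of the scatter. Compound 4 is estimated at 80 nM, likely between 25 nM and 250 nM in this assay.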

Compound 4, half-maximal inhibitory concentration: 99 nM
Compound 4: the middle estimate sits 1.2-fold (0.09 log units) below what was measured; low and high end bracket the measured number.
By their numbers in this assay, from the lowest: compound 3; then compounds 2, 4 and 1 (each within the scatter of the next).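

In this assay, among the compounds shown here, methoxy in place of trifluoromethyl on this aromatic carbon gives a 1.5-fold lower number from compound 1 to compound 4 (0.18 log units; within the scatter), the first direct comparison at this position. Exchanging these two groups therefore has no effect here that can be told apart from the scatter, even though methoxy has fewer heavy atoms and brings a hydrogen-bond acceptor. No measurement is available that could explain this result. On these data alone, whether an amine or a carboxylic acid on this carbon would also stay within the scatter of compound 1 remains open.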